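This account rests on a few compounds, and the source may have more. Where it says the series, first, only, none or still open, it means among the compounds named here.

Three sulfated oligosaccharides carrying the same aryl-amide lipoyl tail were compared in an assay on isolated protein for binding affinity to fibroblast growth factor 2 (Homo sapiens), read by surface plasmon resonance; on this read-out higher numbers stand for weaker binding and lower numbers for tighter binding. Compound 1 `CC(=O)N[C@H]1[C@@H](OC[C@@H](O)[C@@H](O)[C@H](O)[C@@H](O)CNc2cccc(NC(=O)CCCCC3CCSS3)c2)O[C@H](COS(=O)(=O)O)[C@H](O)[C@@H]1O[C@@H]1O[C@H](C(=O)O)[C@@H](O)[C@H](O)[C@H]1O` gives 36 nM. Compound 2 `CC(=O)N[C@H]1[C@@H](OC[C@@H](O)[C@@H](O)[C@H](O)[C@@H](O)CNc2cccc(NC(=O)CCCCC3CCSS3)c2)O[C@H](COS(=O)(=O)O)[C@H](O)[C@@H]1O[C@@H]1O[C@H](C(=O)O)[C@@H](O)[C@H](OS(=O)(=O)O)[C@H]1O` gives 147 nM; it differs from compound 1 only by sulfo in place of hydrogen on an oxygen on a saturated carbon, and that change produced a 4.1-fold higher number from compound 1 to compound 2 (0.61 log units; beyond the scatter). Compound 3 `CC(=O)N[C@H]1[C@@H](OC[C@@H](O)[C@@H](O)[C@H](O)[C@@H](O)CNc2cccc(NC(=O)CCCCC3CCSS3)c2)O[C@H](CO)[C@H](O)[C@@H]1O[C@@H]1O[C@H](C(=O)O)[C@@H](O)[C@H](OS(=O)(=O)O)[C@H]1OS(=O)(=O)O` gives 95 nM; how its core differs from that of compound 1 is not broken down here, and its value sits within the scatter of compound 2 while lying beyond it relative to compound 1.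

Compound 4 `CC(=O)N[C@H]1[C@@H](OC[C@@H](O)[C@@H](O)[C@H](O)[C@@H](O)CNc2cccc(NC(=O)CCCCC3CCSS3)c2)O[C@H](CO)[C@H](OS(=O)(=O)O)[C@@H]1O[C@@H]1O[C@H](C(=O)O)[C@@H](O)[C@H](OS(=O)(=O)O)[C@H]1OS(=O)(=O)O` is not yet measured. It differs from compound 3 by sulfo in place of hydrogen on an oxygen on a saturated carbon, the same change made from compound 1 to compound 2. Because that earlier change gave a 4.1-fold higher number from compound 1 to compound 2 (0.61 log units; beyond the scatter), a weakening step is expected here too, estimated as a 2.5-fold higher number from compound 3 to compound 4 (0.40 log units; beyond the scatter), and compound 4 is expected to give 240 nM in this assay, roughly between 80 nM and 700 nM.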

Compound 4, dissociation constant: 52 nM
For compound 4 the middle estimate is 4.6-fold (0.66 log units) above the measured one, outside the stated range (below it).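

In this assay, sulfo in place of hydrogen on an oxygen on a saturated carbon gave a 1.8-fold lower number from compound 3 to compound 4 (0.26 log units; within the scatter), so the weakening seen on the core of compound 1 did not carry over to this second core. The two steps are distinct, and the change cannot be treated as having one transferable effect in this series: the same change on two cores in this assay, a 4.1-fold higher number (0.61 log units; beyond the scatter) from compound 1 to compound 2 and a 1.8-fold lower number (0.26 log units; within the scatter) from compound 3 to compound 4, 7.5-fold (0.87 log units) apart, beyond the scatter of two such steps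

With a single pair on each core, this does not show which feature of the cores sets the outcome, nor how other cores would respond. The compounds shown leave open whether a phosphate in place of the sulfo group would give a similar step on either core. They also leave open how a longer chain in the tail would affect these values.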